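This account rests on a few compounds, and the source may have more. Where it says the series, first, only, none or still open, it means among the compounds named here.

Measured compounds:
compound 1 `O=C(C(Nc1ccccc1F)c1ccc(C(F)(F)F)cc1)N1CCCC1c1cccc(F)c1`, 9 nM
compound 2 `O=C(C(Nc1ccccc1F)c1ccc(C(F)(F)F)cc1)N1CCCC1c1ccccn1`, 25 nM

Of the compounds shown here, two of the shared core have been measured in an assay on HEK293 cells for antagonist activity at transient receptor potential M8 protein (Canis lupus familiaris), read by fluorescence and calcium flux, with a stated time of 5 min; a lower number here means a stronger inhibitor, a higher number a weaker inhibitor. Compound 1 gives 9 nM and compound 2 gives 25 nM. Within the data shown here, the one step between them, a 2.8-fold higher number from compound 1 to compound 2 (0.44 log units; beyond the scatter), concerns the group on the saturated ring carbon only. Compound 2 thus stands with the higher of the two numbers, and the step to compound 1 lies beyond the scatter.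

Compound 3 `O=C(C(Nc1ccccc1F)c1cc2ccccc2s1)N1CCCC1c1ccccn1` keeps the pyridin-2-yl of compound 2 and changes a different place: 1-benzothiophen-2-yl in place of 4-(trifluoromethyl)phenyl on a saturated chain carbon bound to a carbonyl carbon and a nitrogen on an aromatic ring. No measured step touches this position; the only step shown, the one from compound 1 to compound 2, is at the saturated ring carbon and gives no guide here. Among the measured compounds shown here, the replacement keeps the atom count close and adds one hydrogen-bond acceptor, so no step in this assay beyond the scatter is firmly expected, but the range must be kept wide. For compound 3 the estimate is 40 nM with a range of 10 nM to 160 nM, which means an expected step of a 1.6-fold higher number from compound 2 to compound 3 (0.20 log units; within the scatter).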

Compound 3, half-maximal inhibitory concentration: 8 nM
The estimate for compound 3 lay 5.0-fold (0.70 log units) above the measured number, and the stated range ends above it.
By their numbers in this assay, from the lowest: compounds 3 and 1 (each within the scatter of the next); then compound 2.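

In this assay, the saturated chain carbon bound to a carbonyl carbon and a nitrogen on an aromatic ring now has a measured step of its own: a 3.1-fold lower number from compound 2 to compound 3 (0.49 log units; beyond the scatter) comes with 1-benzothiophen-2-yl in place of 4-(trifluoromethyl)phenyl. With pyridin-2-yl on the saturated ring carbon, this position therefore does not depend on the 4-(trifluoromethyl)phenyl group, and a group with two aromatic rings, sulfur and no fluorine is accepted there with a stronger result. No measurement at hand bears on the origin of this step, and a single pair cannot separate the contributions of the sulfur, the second ring and the loss of the trifluoromethyl group.

On these data alone, it remains open whether the same replacement gives a similar step with the 3-fluorophenyl of compound 1 on the saturated ring carbon. As far as these compounds go, the response of this position to a plain phenyl, a 1-benzofuran-2-yl, an amine, a carboxylic acid or a longer chain also remains open, and these groups would show how far the series tolerates change here.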